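This account rests on a few compounds, and the source may have more. Where it says the series, first, only, none or still open, it means among the compounds named here.

Of the compounds shown here, two have been measured in a functional assay on A549 cells (Homo sapiens) for inhibition, read by MTT assay, with a stated time of 72 h; a higher number here means a weaker inhibitor, a lower number a stronger inhibitor. Compound 2 `O=C(Nc1ccc(Oc2ccnc3[nH]ccc23)c(F)c1)c1cn(-c2ccc(Br)cc2)c2ccccc2c1=O` gives 950 nM, the lowest of the two numbers. Compound 1 `Cn1ccc2c(Oc3ccc(NC(=O)c4cn(-c5ccc(C(F)(F)F)cc5Cl)c5ccccc5c4=O)cc3F)ccnc21` gives 2050 nM in this assay, a higher number than compound 2 by a margin beyond the usual scatter. Among the measured compounds shown here, no single-change step between them is available, as they differ in more than one place.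

Compound 3 `O=C(Nc1ccc(Oc2ccnc3[nH]ccc23)c(F)c1)c1cn(-c2ccc(C(F)(F)F)cc2Cl)c2ccccc2c1=O` is the next compound to be measured. It differs from compound 2 by 2-chloro-4-(trifluoromethyl)phenyl in place of 4-bromophenyl on an aromatic nitrogen. Compound 1 carries the same 2-chloro-4-(trifluoromethyl)phenyl group but differs from compound 3 in a second place as well, so its value cannot be read as the effect of this change alone.

On the two numbers available, compound 3 is expected to give a somewhat higher number than compound 2 in this assay, with the step of a 1.6-fold higher number from compound 2 to compound 3 (0.20 log units; within the scatter) estimated to be modest and possibly within the scatter. Compound 3 is expected to give about 1500 nM, in a range from 600 nM to 4000 nM.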

Compound 3, half-maximal inhibitory concentration: 1620 nM
Compound 3: the middle estimate sits 1.1-fold (0.03 log units) below what was measured; measured number inside the range.
By their numbers in this assay, from the lowest: compounds 2, 3 and 1 (each within the scatter of the next, the first and the last beyond it).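

In this assay, among the compounds shown here, the exchange of 4-bromophenyl for 2-chloro-4-(trifluoromethyl)phenyl on the aromatic nitrogen gives a 1.7-fold higher number from compound 2 to compound 3 (0.23 log units; within the scatter) and so, read alone for the first time, this change does not separate the two compounds at this position. The second change can now be read alone too: hydrogen in place of methyl on an aromatic nitrogen gives a 1.3-fold lower number from compound 1 to compound 3 (0.10 log units; within the scatter) and this pair is likewise not separated, so neither change alone accounts for the gap beyond the scatter between compound 1 and compound 2. Nothing available gives a reason for the size of either step.

From the compounds shown here alone, it remains open whether a quite different group on the first nitrogen, such as a pyridyl ring or a phenyl carrying a morpholine, would shift the number beyond the scatter. Going by these compounds, it is equally open whether an ethyl group or a longer chain in place of the methyl of compound 1 would do so.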